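Bromo in place of hydrogen on the fused ring of compound 2

The source may hold more compounds than are shown below. What is called first, only, known or untested is meant among the compounds shown, and "the series" means these compounds.

Measured compounds:
compound 1 `N#Cc1ccc(C(=O)N[C@@H]2CN[C@H](C(=O)N3CCSC3)C2)cc1`, 34.1 nM
compound 2 `O=C([C@@H]1C[C@H](N2CCc3ccccc32)CN1)N1CCSC1`, 19.5 nM

In an assay on a cell-free system (plasma) for inhibition of Dipeptidyl peptidase 4 (Rattus norvegicus), read by fluorescence (a lower number here means a stronger inhibitor, a higher number a weaker inhibitor), compound 1 gives 34.1 nM. In this assay compound 2 gives 19.5 nM. Compound 2 carries the lowest of the two numbers, and its nearest neighbour is compound 1; the gap between the two lies within the scatter, so the two compounds cannot be told apart on these numbers. Within the data shown here, no pair of measured compounds differs in a single place, so no measured step is available for comparison.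

Compound 3 `O=C([C@@H]1C[C@H](N2CCc3cc(Br)ccc32)CN1)N1CCSC1` is built on compound 2 and differs from it by bromo in place of hydrogen on an aromatic carbon. Among the measured compounds shown here, nothing measured so far shows what a bromo in place of hydrogen on this ring does in this assay. The expectation is therefore a step of no more than the scatter, with no direction favoured, which is what a 1.3-fold lower number from compound 2 to compound 3 (0.11 log units; within the scatter) expresses. Compound 3 is estimated at 15 nM, with a range from 5 nM to 50 nM that allows for a modest move either way.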

Compound 3, half-maximal inhibitory concentration: 10.7 nM
Estimate against measurement, compound 3: 1.4-fold (0.15 log units) above; low and high end bracket the measured number.
By their numbers in this assay, from the lowest: compounds 3, 2 and 1 (each within the scatter of the next, the first and the last beyond it).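

In this assay, bromo in place of hydrogen on this aromatic carbon, meta to a fused ring and para to a fused ring, gives a 1.8-fold lower number from compound 2 to compound 3 (0.26 log units; within the scatter) and so leaves compound 2 and compound 3 indistinguishable on these numbers. Among these compounds, this is the first single-place comparison, and it shows that this carbon of the fused system can carry a bromine atom with no step beyond the scatter. No measurement at hand bears on why the reading holds at this position.

As far as these compounds go, it remains open whether fluoro, a methoxy group or an amine on this same aromatic carbon would stay within the scatter of compound 2 or move beyond it. From the compounds shown here alone, it also remains open whether bromo on the other aromatic carbons of this ring reads the same, since a single step at one carbon supports no wider pattern.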